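Methylating the Phenol of Compound 2

A few compounds are considered here, and "the series" means these few. Any claim that something is new, unique, unknown or untested is made for them only; others in the source may bear on it.

Compound 1 `CN1CCC[C@H]1[C@H]1COc2ccc(Br)cc2O1` gives 3000 nM in an assay on Cerebral cortex (strain Sprague-Dawley) for displacement of a labelled ligand from Neuronal acetylcholine receptor; alpha4/beta2 (Rattus norvegicus); a higher number here means a weaker inhibitor, a lower number a stronger inhibitor.
Compound 2 `CN1CCC[C@H]1[C@H]1COc2ccc(O)cc2O1` gives 421 nM in this assay.

Going by the values given here, compound 2 holds the lower of the two numbers; its only neighbour is compound 1, reached by a 7.1-fold lower number from compound 1 to compound 2 (0.85 log units; beyond the scatter). Compound 3 `COc1ccc2c(c1)O[C@@H]([C@@H]1CCCN1C)CO2` carries methyl in place of hydrogen on an oxygen on an aromatic ring. Among the compounds with values here, no measured step covers this kind of change: the single known step, the exchange of bromo for hydroxy, moved the number by a 7.1-fold lower number from compound 1 to compound 2 (0.85 log units; beyond the scatter), but says nothing about capping that oxygen with a methyl. With no guide from the data, compound 3 is estimated at 1000 nM, expected to fall between 300 nM and 3500 nM, a step of a 2.4-fold higher number from compound 2 to compound 3 (0.38 log units; beyond the scatter) that leans toward a weaker inhibitor.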

Compound 3, inhibition constant: 4200 nM
The estimate for compound 3 lay 4.2-fold (0.62 log units) below the measured number; measured number above the stated range.
By their numbers in this assay, from the lowest: compound 2; then compounds 1 and 3 (each within the scatter of the next).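

In this assay, capping the oxygen with a methyl gives a 10-fold higher number from compound 2 to compound 3 (1.00 log units; beyond the scatter) and so shows that the change from hydroxy to methoxy at this position is not a silent one. Methoxy in place of bromo gives a 1.4-fold higher number from compound 1 to compound 3 (0.15 log units; within the scatter) and so leaves these two groups indistinguishable here, with only the hydroxy of compound 2 standing apart from both. Going by these compounds, whether an amine in place of the hydroxy, or a longer chain such as ethoxy on the oxygen, would give a low number remains open. Nothing available explains why this methyl has such an effect.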